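This account rests on a few compounds, and the source may have more. Where it says the series, first, only, none or still open, it means among the compounds named here.

compound 1 `C#CC1=CC[C@@]2(C)C(=C)CCC[C@]2(C)CC1` gives 148000 nM
compound 2 `C#CC1=CC[C@]2(CC1)C(=C)CC[C@H]2C(C)C` gives 103000 nM
compound 3 `C=C1CCC[C@]2(C)CCC(c3cn(-c4ccc(C(C)=O)cc4)nn3)=CC[C@@]12C` gives 46400 nM

These numbers all come from a functional assay on A549 cells (Homo sapiens) for cytotoxicity, read by MTT assay, with a stated time of 48 h (a lower number here means a stronger inhibitor, a higher number a weaker inhibitor), and give a first view of the series. Compound 3 has the lowest number of the three, and its gaps to compound 2 and to compound 1 both lie beyond the usual scatter of repeated measurements.

Compound 4 `C=C1CCC[C@]2(C)CCC(c3cn(-c4cccc(OC)c4)nn3)=CC[C@@]12C` has not been measured yet. It keeps the core of compound 3 and changes one group, with 3-methoxyphenyl in place of 4-acetylphenyl on an aromatic nitrogen of a five-membered aromatic ring with 3 nitrogen. The counted difference 3-methoxyphenyl in place of 4-acetylphenyl on an aromatic nitrogen describes this swap in full.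

Among the measured compounds shown here, no pair of measured compounds differs at this place alone, so the data give no direct guide to the size of the step in this assay. For the measured compounds named here, with compound 3 at 46400 nM as the lowest of only three numbers, a small drift toward a higher number seems more likely than a drop, though no step beyond the scatter is the main expectation. The estimated step of a 1.2-fold higher number from compound 3 to compound 4 (0.07 log units; within the scatter) is expected to stay within that scatter. For compound 4 the expected value is 55000 nM in an estimated range from 22000 nM to 130000 nM as the likely span of a measurement.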

Compound 4, half-maximal inhibitory concentration: 11200 nM
Compound 4: middle estimate off by 4.9-fold (0.69 log units), on the high side; measured number outside the range, below it.
By their numbers in this assay, from the lowest: compound 4; then compound 3; then compounds 2 and 1 (each within the scatter of the next).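

In this assay, replacing 4-acetylphenyl with 3-methoxyphenyl on the aromatic nitrogen gives a 4.1-fold lower number from compound 3 to compound 4 (0.62 log units; beyond the scatter) and leaves the shared core untouched, so the group at this position can move the result by more than the scatter. The two groups have the same counts of hydrogen-bond donors and acceptors, so those counts do not separate them, while 3-methoxyphenyl has fewer heavy atoms and lacks the double bond outside aromatic rings that 4-acetylphenyl carries. Nothing available explains the lower number, and this single pair cannot tell whether it comes from the kind of group on the phenyl ring or from where that group sits.

Going by these compounds, it remains open how a plain phenyl, or a phenyl carrying an amine or a carboxylic acid, would compare with these two groups, and so whether the trend reaches further along this position. Also open is whether the same swap would give a step of similar size on the core of compound 2, since the compounds shown test it on only one core.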